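A few compounds are considered here, and "the series" means these few. Any claim that something is new, unique, unknown or untested is made for them only; others in the source may bear on it.

Measured so far in a functional assay on MDA-MB-231 cells (Homo sapiens) for antiproliferative activity, read by MTT assay, with a stated time of 48 h; a higher number here means a weaker inhibitor of growth, a lower number a stronger inhibitor of growth:
compound 1 `COC(=O)N1N=C(c2ccccc2)CC1c1cc(OC)c(OC)c(OC)c1`: 1080 nM
compound 2 `COC(=O)N1N=C(c2ccccc2)CC1c1ccc(OC)cc1`: > 10000 nM (a limit)

Compound 2 has no number in this assay: its > 10000 nM is a limit of the assay. Of the two measured compounds, only compound 1 gives a number, at 1080 nM.

The next compound is compound 3 `COC(=O)N1N=C(c2ccccc2)CC1c1ccc(OC)c(OC)c1`. It keeps the structure of compound 2 except for one change, methoxy in place of hydrogen on an aromatic carbon, ortho to a methoxy group and meta to a large group: methoxy in place of hydrogen on an aromatic carbon.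

The expectation rests on compound 1, which gives 1080 nM and carries more methoxy groups on that ring than compound 2 does. Compound 3 is therefore expected to move towards stronger inhibition of growth, though only modestly, and it could again return only a limit. The expected size of the change is uncertain, and the estimated step is an at least 2.2-fold lower number from compound 2 to compound 3 (0.34 log units; beyond the scatter). In this assay, compound 3 is estimated at 4500 nM, with an expected range from 1500 nM to 10000 nM.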

Compound 3, concentration for 50% growth inhibition: 8940 nM
Beside the measured number, compound 3's estimate is 2.0-fold (0.30 log units) below it; the measured number falls inside the stated range.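

In this assay, placing a methoxy on the aromatic carbon ortho to a methoxy group and meta to a large group gives an at least 1.1-fold lower number from compound 2 to compound 3 (0.04 log units; that floor lies within the scatter), so this change alone is not shown to shift growth inhibition beyond the usual variation between repeats. That reading is only a floor because compound 2 has a limit of the assay rather than a number: the limit of > 10000 nM in this assay, at which 1 of the 3 values shown sits. Removing one methoxy from the fully substituted ring gives an 8.3-fold higher number from compound 1 to compound 3 (0.92 log units; beyond the scatter), which shows that the ring's remaining methoxy groups do not account for the activity on their own and that the further methoxy of compound 1 matters in this assay.

As far as these compounds go, it remains open how much the methoxy added in compound 3 truly contributes, since the size of that step is bounded on one side only. From the compounds shown here alone, it is also open whether a hydroxy group, a chlorine atom or a longer chain such as ethoxy on the same aromatic carbon would behave like methoxy, or whether an amine there would change the outcome in this assay.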